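The source may hold more compounds than are shown below. What is called first, only, known or untested is meant among the compounds shown, and "the series" means these compounds.

Working notes on the series. Compound 1 `C=C(C)C(=O)N1CCC(CN(C2Cc3cc(C#N)ccc3N(Cc3cncn3C)C2)S(=O)(=O)c2ccccn2)CC1`, compound 2 `Cn1cncc1CN1CC(N(CC2CCN(C(=O)Nc3ccc(Br)cc3)CC2)S(=O)(=O)c2ccccn2)Cc2cc(C#N)ccc21` and compound 3 `Cn1cncc1CN1CC(N(CC2CCN(C(=O)c3cccs3)CC2)S(=O)(=O)c2ccccn2)Cc2cc(C#N)ccc21` share one core and differ only in the group on a carbonyl carbon. In an ADME assay on Caco-2 cells (Homo sapiens) for permeability, in the apical to basolateral direction (on this read-out lower numbers stand for lower permeability and higher numbers for higher permeability), compound 1 gives 0.5 10^-6 cm/s. In this assay compound 2 gives 0.6 10^-6 cm/s. In this assay compound 3 gives 0.5 10^-6 cm/s. The three measured steps are small: a 1.2-fold higher number from compound 1 to compound 2 (0.08 log units; within the scatter), no change at the digits printed from compound 1 to compound 3 (within the scatter) and a 1.2-fold lower number from compound 2 to compound 3 (0.08 log units; within the scatter). Compound 3 therefore stands level with compound 1 at the digits printed, the two together being the lowest of the three numbers, and its furthest neighbour is compound 2, with a 1.2-fold lower number from compound 2 to compound 3 (0.08 log units; within the scatter).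

Compound 4 `CC(C)S(=O)(=O)N1CCC(CN(C2Cc3cc(C#N)ccc3N(Cc3cncn3C)C2)S(=O)(=O)c2ccccn2)CC1` is the next member. (isopropylsulfonyl in place of (thiophen-2-yl)carbonyl on an amine nitrogen in a ring). Among the compounds with values here, no measured step touches this same place in the same way: each of the three exchanges a group on a carbonyl carbon and keeps the carbonyl, whereas here the carbonyl and its thiophen-2-yl leave together and isopropylsulfonyl enters. The bearing of the measured steps is thus indirect, and all three lay within the scatter, so no step beyond the scatter is expected from compound 3 to compound 4, that is no change at the digits printed from compound 3 to compound 4 (within the scatter). In this assay compound 4 is estimated at 0.5 10^-6 cm/s, with a range from 0.25 10^-6 cm/s to 1 10^-6 cm/s.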

Compound 4, apparent permeability: 0.1 10^-6 cm/s
For compound 4 the middle estimate is 5.0-fold (0.70 log units) above the measured one, and the stated range ends above it.
By their numbers in this assay, from the lowest: compound 4; then compounds 1, 3 and 2 (each within the scatter of the next).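

In this assay, within the data shown here, the exchange on the amine nitrogen in the six-membered ring gives the first steps that lie beyond the scatter, all three with isopropylsulfonyl as the entering group (a 5.0-fold lower number from compound 3 to compound 4 (0.70 log units; beyond the scatter); a 6.0-fold lower number from compound 2 to compound 4 (0.78 log units; beyond the scatter); a 5.0-fold lower number from compound 1 to compound 4 (0.70 log units; beyond the scatter)). Changes on the carbonyl carbon among 1-methylethenyl, (4-bromophenyl)amino and thiophen-2-yl stayed within the scatter in compounds 1, 2 and 3, whereas removing the carbonyl along with its group and introducing isopropylsulfonyl gives compound 4 a clearly lower number than each of them, so this position is not indifferent to every change made there. No measurement at hand speaks to the reason for these steps.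

The compounds shown leave open whether the lower number goes with the sulfonyl link or with the isopropyl group, as the two enter together; a thiophen-2-ylsulfonyl group or an isopropylcarbonyl group on the same nitrogen would separate them. Also open, as far as these compounds go, is where a methylsulfonyl group, a longer alkylsulfonyl chain or a phenylsulfonyl group would stand relative to compound 4.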